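Working notes: methyl for fluoro after compound 3

The source may hold more compounds than are shown below. What is called first, only, known or untested is meant among the compounds shown, and "the series" means these compounds.

Measured in a functional assay on U-87MG ATCC cells for antiproliferative activity against U-87 MG (Homo sapiens), read by spectrophotometry, with a stated time of 2 days (a lower number here means a stronger inhibitor of growth, a higher number a weaker inhibitor of growth), so far:
- compound 1 `Cc1ccc(Nc2ncc(C(F)(F)F)c(N3Cc4cccc(N(C)S(C)(=O)=O)c4C3)n2)c(Cl)c1` gives > 30000 nM as a limit of the assay
- compound 2 `COc1cc(Nc2ncc(C(F)(F)F)c(N3Cc4cccc(N(C)S(C)(=O)=O)c4C3)n2)c(OC)cc1Cl` gives 6200 nM as a number
- compound 3 `Cc1cc(F)ccc1Nc1ncc(C(F)(F)F)c(N2Cc3cccc(N(C)S(C)(=O)=O)c3C2)n1` gives > 30000 nM as a limit of the assay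

Compound 3 has no number, and it stands with compound 1 in the limit of > 30000 nM in this assay, at which 2 of the 3 values shown sit, as the whole of the series' limit readings. Compound 4 `Cc1ccc(Nc2ncc(C(F)(F)F)c(N3Cc4cccc(N(C)S(C)(=O)=O)c4C3)n2)c(C)c1` differs from compound 3 by one change, (methyl in place of fluoro on an aromatic carbon), which is methyl in place of fluoro on an aromatic carbon, para to a large group and meta to a methyl group. The substituent thus goes from 4-fluoro-2-methylphenyl to 2,4-dimethylphenyl.

Within the data shown here, no measured step makes this exact change. Only the substituent of compound 2 has given a readable number, as an at least 4.8-fold lower number from compound 1 to compound 2 (0.68 log units; beyond the scatter) and an at least 4.8-fold higher number from compound 2 to compound 3 (0.68 log units; beyond the scatter) both show. The remaining comparison is a step that the two limits leave unreadable from compound 1 to compound 3 and so gives no size. Compound 4 resembles compound 1 and compound 3 more than compound 2, so it is expected to stay weak. The estimated change is a number no higher from compound 3 to compound 4 (the limit leaves the size open) with no readable gain expected. The estimate for compound 4 is 30000 nM with an expected range from 12000 nM to 60000 nM and most likely only a limit will be reported.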

Compound 4, concentration for 50% growth inhibition: > 30000 nM
Compound 4 was reported as a limit; the forecaster's own chance of this, stated with the estimate: 80%; the middle value sits exactly at the limit.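

With methyl in place of fluoro on an aromatic carbon, para to a large group and meta to a methyl group, the 2,4-dimethylphenyl of compound 4 stays at the limit of this assay, as do the 4-fluoro-2-methylphenyl of compound 3 and the 2-chloro-4-methylphenyl of compound 1, so methyl at this place gives no readable growth inhibition. The steps to compound 4 from compound 3 and from compound 1 have limits at both ends and cannot be read, and this limit now holds most of the series: the limit of > 30000 nM in this assay, at which 3 of the 4 values shown sit.

The only readable comparison for compound 4 is an at least 4.8-fold higher number from compound 2 to compound 4 (0.68 log units; beyond the scatter), which leaves the 4-chloro-2,5-dimethoxyphenyl of compound 2 as the only substituent shown with a number.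

The compounds shown do not separate the chloro from the two methoxy groups of compound 2, so which of these carries its reading stays open. Also open, going by these compounds, is how an amine or a carboxylic acid on an aromatic carbon, para to a large group, would read against this limit.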